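A Hydroxy Group Enters: Expected Cytotoxicity of Compound 3

This account rests on a few compounds, and the source may have more. Where it says the series, first, only, none or still open, it means among the compounds named here.

Of the compounds shown here, two sharing one core have been measured in a functional assay on HepG2 cells (Homo sapiens) for cytotoxicity, read by MTT assay, with a stated time of 48 h; on this read-out lower numbers stand for stronger inhibition and higher numbers for weaker inhibition. Compound 1 `O=C(CSc1nnc(-c2ccncc2)o1)N/N=C/c1ccc([N+](=O)[O-])cc1` gives 17900 nM. Within the data shown here, compound 2 `COc1ccc(/C=N/NC(=O)CSc2nnc(-c3ccncc3)o2)cc1` gives 15800 nM in this assay; the only other number, that of compound 1, lies within the scatter of it, so the two cannot be told apart. The step of a 1.1-fold lower number from compound 1 to compound 2 (0.05 log units; within the scatter) confirms this. Compound 3 `COc1cc(/C=N/NC(=O)CSc2nnc(-c3ccncc3)o2)ccc1O` has not yet been measured. It differs from compound 2 in one place: 4-hydroxy-3-methoxyphenyl in place of 4-methoxyphenyl on a carbon with a double bond to nitrogen. Among the measured compounds shown here, no measured step bears directly on this change; the one step known, a 1.1-fold lower number from compound 1 to compound 2 (0.05 log units; within the scatter), swapped one substituent for another on the same ring and stayed within the scatter, giving no reason to expect a large move. Compound 3 is therefore expected to give about 15000 nM in this assay, with a likely range of 6000 nM to 40000 nM. The step of a 1.1-fold lower number from compound 2 to compound 3 (0.02 log units; within the scatter) is thus expected to be none beyond the scatter.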

Compound 3, half-maximal inhibitory concentration: 2920 nM
For compound 3 the middle estimate is 5.1-fold (0.71 log units) above the measured one; the measured number lies below the stated range.
By their numbers in this assay, from the lowest: compound 3; then compounds 2 and 1 (each within the scatter of the next).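

Putting 4-hydroxy-3-methoxyphenyl in place of 4-methoxyphenyl gives a 5.4-fold lower number from compound 2 to compound 3 (0.73 log units; beyond the scatter) in this assay, so the group on this carbon with a double bond to nitrogen can change the result after all. The earlier swap of nitro for methoxy, a 1.1-fold lower number from compound 1 to compound 2 (0.05 log units; within the scatter), gave no sign of this, whereas 4-hydroxy-3-methoxyphenyl in place of 4-nitrophenyl gives a 6.1-fold lower number from compound 1 to compound 3 (0.79 log units; beyond the scatter), and so compound 3 stands apart from both earlier compounds. No supporting measurement is available to explain this difference.

The compounds shown leave open whether the hydroxy group alone carries the change, which 4-hydroxyphenyl would test, or whether the methoxy group must be present as well. Also open, on these data alone, is how an amine or a carboxylic acid on this aromatic ring would behave.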